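The source may report more compounds than this note shows. Statements on the series, on what has been measured and on what is new or still open speak of the compounds shown alone.

Two compounds carrying a hydroxy group open the series. In a functional assay on MCF7 cells (Homo sapiens) for cytotoxicity (a higher number here means a weaker inhibitor, a lower number a stronger inhibitor), compound 1 (`Nc1ccc(-c2nc3c(O)cccc3s2)cc1Cl`) gives 61400 nM. Compound 2 (`Nc1ccc(-c2nc3cc(O)ccc3s2)cc1Cl`), with its hydroxy at another place on the shared core, gives 60600 nM, which stands level with compound 1, within the scatter. The next compound is compound 3 (`Nc1ccc(-c2nc3ccccc3s2)cc1Cl`), in which hydrogen takes the place of hydroxy on an aromatic carbon: hydrogen in place of hydroxy on an aromatic carbon. For the measured compounds named here, no compound without the hydroxy has been measured yet, so no measured step guides this change. Both hydroxy compounds sit at the same level, and the expectation is a large step in this assay towards a lower number, though its size is very uncertain. The expected change is a 610-fold lower number from compound 2 to compound 3 (2.78 log units; beyond the scatter). For compound 3 the estimated value is 100 nM, with an expected range from 2 nM to 5000 nM.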

Compound 3, half-maximal inhibitory concentration: < 1 nM
Compound 3: a limit, no number; the forecaster's own chance of this, stated with the estimate: 15%; middle value at least 100-fold (2.00 log units) from the limit.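

In this assay compound 3 gives < 1 nM, which is a limit of the assay and not a number. The two hydroxy compounds stood level with each other, so moving the hydroxy showed almost nothing, whereas replacing it with hydrogen gives an at least 60000-fold lower number from compound 2 to compound 3 (4.78 log units; beyond the scatter), and the same change at the other place gives an at least 61000-fold lower number from compound 1 to compound 3 (4.78 log units; beyond the scatter). Both steps are therefore lower bounds, and their true size stays unknown: the limit of < 1 nM in this assay, at which 1 of the 3 values shown sits.

The compounds shown leave open whether the large step belongs to the hydroxy in particular or whether any group on this aromatic carbon would raise the number. A methoxy group, a fluorine atom or an amine at either place could tell these two readings apart.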